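This account rests on a few compounds, and the source may have more. Where it says the series, first, only, none or still open, it means among the compounds named here.

Measured so far in a toxicity assay on the whole organism (strain Icem-CET (SPF Caw)) for cytotoxicity, with Mus musculus as the target; on this read-out lower numbers stand for an effect already at smaller amounts and higher numbers for an effect only at larger amounts of compound:

Compound 1 `C=CCNC(=O)/C(C)=C(/C)c1ccc(OC)cc1` gives 280 mg/kg in this assay.
Compound 2 `C=CCNC(=O)/C(C)=C(/C)c1ccc(Cl)cc1` gives 180 mg/kg in this assay.
Compound 3 `C=CCNC(=O)/C(C)=C(/C)c1ccccc1` gives 550 mg/kg in this assay.

Compound 3 stands at the highest of the three numbers. Its nearest neighbour is compound 1, a step that lies within the scatter: a 2.0-fold higher number from compound 1 to compound 3 (0.29 log units; within the scatter). Its furthest neighbour is compound 2, and that step is beyond the scatter, though modest: a 3.1-fold higher number from compound 2 to compound 3 (0.49 log units; beyond the scatter). Between compound 1 and compound 2 the difference is within the scatter: a 1.6-fold lower number from compound 1 to compound 2 (0.19 log units; within the scatter).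

Compound 4 `C=CCNC(=O)/C(C)=C(/C)c1ccc(C)cc1` is the compound still to be measured. It differs from compound 3 in one place: methyl in place of hydrogen on an aromatic carbon.

Among the measured compounds shown here, the steps that bear on this change are the two in which a group on that aromatic carbon was removed to give compound 3, namely a 2.0-fold higher number from compound 1 to compound 3 (0.29 log units; within the scatter) and a 3.1-fold higher number from compound 2 to compound 3 (0.49 log units; beyond the scatter). Both ran toward a higher number when the group left; putting a group back is therefore expected to run the other way, by a small to modest amount, with a fair chance that the step stays within the scatter.

Compound 4 is thus estimated at 300 mg/kg in this assay, in the range 150 mg/kg to 600 mg/kg, which corresponds to an expected step of a 1.8-fold lower number from compound 3 to compound 4 (0.26 log units; within the scatter).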

Compound 4, dose for half-maximal effect: 280 mg/kg
Compound 4: the middle estimate sits 1.1-fold (0.03 log units) above what was measured; the range from low to high includes it.
By their numbers in this assay, from the lowest: compounds 2, 1, 4 and 3 (each within the scatter of the next, the first and the last beyond it).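

In this assay, a small carbon-only group on this aromatic carbon, para to a large group, gives a step that stays within the scatter: a 2.0-fold lower number from compound 3 to compound 4 (0.29 log units; within the scatter). Compound 4 also cannot be told apart from the other two substituted compounds, with a 1.6-fold higher number from compound 2 to compound 4 (0.19 log units; within the scatter) and no change at the digits printed from compound 1 to compound 4 (within the scatter), so methyl, chloro and methoxy do not separate in this assay, although these groups differ in their atoms. Among the compounds shown here, this leaves a 3.1-fold higher number from compound 2 to compound 3 (0.49 log units; beyond the scatter) as the only step among the four compounds that lies beyond the scatter, so the effect of replacing hydrogen at this position is clear for chloro alone, and the methyl and methoxy compounds do not share that clear separation from compound 3.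

The compounds shown leave open whether an amine, a carboxylic acid or a longer chain such as butyl on this carbon would stay with these three groups or move clearly away from them, and whether the same groups would behave alike on another carbon of the ring. Nothing on hand speaks to what lies behind these numbers.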